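Methoxy on the fused ring of compound 2

The source may hold more compounds than are shown below. What is called first, only, known or untested is meant among the compounds shown, and "the series" means these compounds.

Measured so far:
compound 1 `COc1ccc2c(=O)cc(-n3cncn3)oc2c1`, 19 nM in an assay on isolated protein for inhibition of Amine oxidase [flavin-containing] B (Homo sapiens), read by fluorescence, with a stated time of 20 min; a higher number here means a weaker inhibitor, a lower number a stronger inhibitor
compound 2 `O=C1/C(=C/c2cc3ccccc3[nH]2)Oc2ccccc21`, 39 nM in this assay

Of the two numbers, compound 2 gives the higher one; the gap to compound 1 lies beyond the scatter. Compound 3 `COc1ccc2c(c1)O/C(=C\c1cc3ccccc3[nH]1)C2=O` carries methoxy in place of hydrogen on an aromatic carbon. Going by the values given here, no step between measured compounds exists to lean on, and compound 1 differs from compound 2 in more than one place, so only its value stands as a loose hint. A modest move to a lower number is expected, a 2.0-fold lower number from compound 2 to compound 3 (0.29 log units; within the scatter), in line with compound 1 at 19 nM. Compound 3 is estimated at 20 nM, within 6 nM to 70 nM.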

Compound 3, half-maximal inhibitory concentration: 2.6 nM
The estimate for compound 3 lay 7.7-fold (0.89 log units) above the measured number, and the stated range ends above it.
By their numbers in this assay, from the lowest: compound 3; then compound 1; then compound 2.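

In this assay, going by these compounds alone, methoxy in place of hydrogen on an aromatic carbon gives a 15-fold lower number from compound 2 to compound 3 (1.18 log units; beyond the scatter) and thereby supplies the first single-place step. This position on the six-membered aromatic ring of carbon only is therefore sensitive to substitution, which compound 1 could only loosely hint at. (Nothing measured here accounts for the size of this step).

Open, as far as these compounds go, is whether a hydroxyl, a fluorine or a longer chain such as ethoxy on the same carbon would keep the gain. Also open, from the compounds shown here alone, is whether methoxy on the other carbons of that ring would give a comparable step.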